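A Methoxy Substituent in Place of Bromo

The source may report more compounds than this note shows. Statements on the series, on what has been measured and on what is new or still open speak of the compounds shown alone.

Compound 3 `Nc1scc(-c2cccc(Br)c2)c1C(=O)c1ccc(Cl)cc1` gives 62% in a functional assay on CHO cells for agonist activity at adenosine receptor A1 (Homo sapiens), read by fluorescence and ERK phosphorylation, with stated times of 30 min and 1.5 h, tested at 3 uM (on this read-out lower numbers stand for a weaker effect and higher numbers for a stronger effect at the one concentration tested), the second highest of three numbers: compound 1 `Nc1scc(-c2cccc(C(F)(F)F)c2)c1C(=O)c1ccc(Cl)cc1` gives 64%, and compound 2 `Nc1scc(-c2ccccc2)c1C(=O)c1ccc(Cl)cc1` gives 51%. The step of a number 2 percentage points lower from compound 1 to compound 3 (within the scatter) and the step of a number 11 percentage points higher from compound 2 to compound 3 (beyond the scatter) bracket the bromo group. Compound 4 `COc1cccc(-c2csc(N)c2C(=O)c2ccc(Cl)cc2)c1` differs from compound 3 by methoxy in place of bromo on an aromatic carbon. Among the measured compounds shown here, no measured step involves a methoxy group, so the expectation rests on the bromo and hydrogen comparisons alone. Compound 1 and compound 3, each carrying a group on that aromatic carbon, lie within the scatter of each other, while compound 2 lies lower. Compound 4 is therefore expected to show a number 7 percentage points lower from compound 3 to compound 4 (within the scatter). The estimate for compound 4 is 55%, ranging from 40% to 70%.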

Compound 4, a percentage reported as activity, at one concentration (the size of the read-out at that concentration, not a potency): 58%
Compound 4: the middle estimate sits 3 percentage points below what was measured, within the range that was stated.
By their numbers in this assay, from the lowest: compounds 2, 4, 3 and 1 (each within the scatter of the next, the first and the last beyond it).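

Methoxy in place of bromo brings in a hydrogen-bond acceptor, yet the change stays small (a number 4 percentage points lower from compound 3 to compound 4 (within the scatter)), as does methoxy in place of trifluoromethyl (a number 6 percentage points lower from compound 1 to compound 4 (within the scatter)). Methoxy in place of hydrogen is also small (a number 7 percentage points higher from compound 2 to compound 4 (within the scatter)), so compound 4 cannot be separated from compound 2, whereas compound 1 and compound 3 can. Nothing shown here accounts for these results. From the compounds shown here alone, whether an amine or a carboxylic acid on this aromatic carbon would match compound 3 or compound 2 remains open. So does the effect of a longer chain such as ethoxy in place of methoxy.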